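Trading a 1-hydroxyethyl for a methoxy on compound 3

This account rests on a few compounds, and the source may have more. Where it says the series, first, only, none or still open, it means among the compounds named here.

The three measured compounds and their half-maximal inhibitory concentrations in a functional assay on LNCaP cells (Homo sapiens) for antiproliferative activity, read by CCK-8 assay, with a stated time of 6 days (on this read-out lower numbers stand for stronger inhibition and higher numbers for weaker inhibition), are these:

Compound 1, `CC(=O)c1cc(C(=O)N[C@H](C)Cn2ccc(-c3cc(F)c(C#N)c(Cl)c3)n2)n[nH]1`: 1080 nM
Compound 2, `C[C@@H](Cn1ccc(-c2ccc(C#N)c(Cl)c2)n1)NC(=O)c1ccccc1`: 1830 nM
Compound 3, `CC(O)c1ccc(C(=O)N[C@@H](C)Cn2ccc(-c3ccc(C#N)c(Cl)c3)n2)cc1`: 3690 nM

Compound 3 carries the highest number of the three. For the measured compounds named here, its nearest neighbour is compound 2, and the gap between them is the one single-point step on record, a 2.0-fold higher number from compound 2 to compound 3 (0.30 log units; within the scatter), which stays within the scatter. Compound 1 is furthest away; it differs from compound 3 in more than one place, and the gap between its value and that of compound 3 lies beyond the scatter.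

Compound 4, `COc1ccc(C(=O)N[C@@H](C)Cn2ccc(-c3ccc(C#N)c(Cl)c3)n2)cc1`, is compound 3 altered in one place: methoxy in place of 1-hydroxyethyl on an aromatic carbon. Going by the values given here, no measured step swaps one para substituent for another, so the only guidance is indirect: the single recorded step, a 2.0-fold higher number from compound 2 to compound 3 (0.30 log units; within the scatter), shows that putting a 1-hydroxyethyl where a hydrogen stood left the number within the scatter, which suggests that the group at this place does not move the read-out by much. The writer therefore expects a step of a 1.5-fold lower number from compound 3 to compound 4 (0.17 log units; within the scatter), not clearly beyond the scatter in either direction. Compound 4 is estimated at 2500 nM, with a likely range from 1000 nM to 6500 nM.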

Compound 4, half-maximal inhibitory concentration: 3410 nM
The estimate for compound 4 lay 1.4-fold (0.13 log units) below the measured number; measured number inside the range.
By their numbers in this assay, from the lowest: compounds 1, 2, 4 and 3 (each within the scatter of the next, the first and the last beyond it).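

In this assay, replacing 1-hydroxyethyl with methoxy gives a 1.1-fold lower number from compound 3 to compound 4 (0.03 log units; within the scatter), so at this place, on an aromatic carbon para to a large group, the two groups cannot be told apart, even though only 1-hydroxyethyl carries a hydrogen-bond donor. Methoxy in place of hydrogen gives a 1.9-fold higher number from compound 2 to compound 4 (0.27 log units; within the scatter), so hydrogen, 1-hydroxyethyl and methoxy, the three groups now seen at this place on the shared core, all lie within the scatter of one another, and the earlier single step no longer stands alone. No measurement is available that would explain this lack of separation among the three groups.

Going by these compounds, whether an amine, a carboxylic acid or a longer chain at this place would also stay within the scatter remains open, so the result describes only these three groups and not the position as a whole. Compound 1, at 1080 nM, differs from the others in more than one place, which leaves open which of its differences goes with its value.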